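Swapping the Thioimidate Arm for a Benzylcarbamate

The source may hold more compounds than are shown below. What is called first, only, known or untested is meant among the compounds shown, and "the series" means these compounds.

Compound 1 `CC/N=C(\S)OC[C@H]1OC(n2cnc3c(NC4CCOC4)ncnc32)[C@H](O)[C@@H]1O` and compound 2 `O[C@@H]1[C@@H](CO/C(S)=N/C2CCCC2)OC(n2cnc3c(NC4CCOC4)ncnc32)[C@@H]1O` share one core and differ only at the group on the sugar's side-chain oxygen. In an assay on DDT1 cells (Cricetulus griseus) for binding affinity to adenosine receptor A1 (Homo sapiens), read by radioligand binding (on this read-out higher numbers stand for weaker inhibition and lower numbers for stronger inhibition), compound 1 gives 33 nM and compound 2 gives 72 nM, the higher of the two numbers; the step of a 2.2-fold higher number from compound 1 to compound 2 (0.34 log units; beyond the scatter) separates them. Compound 3 `O=C(NCc1ccccc1)OC[C@H]1OC(n2cnc3c(NC4CCOC4)ncnc32)[C@H](O)[C@@H]1O` carries a different group there: a group of 10 heavy atoms (8 carbon, 1 nitrogen, 1 oxygen; one six-membered aromatic ring of carbon only) in place of a group of 8 heavy atoms (6 carbon, 1 nitrogen, 1 sulfur; one five-membered non-aromatic ring of carbon only), on an oxygen on a saturated carbon. Going by the values given here, only that one step informs this change, and it was modest, so compound 3 is expected to sit near compound 2, with the step of a 1.1-fold higher number from compound 2 to compound 3 (0.05 log units; within the scatter). The estimate for compound 3 is 80 nM, spanning 20 nM to 320 nM.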

Compound 3, inhibition constant: 1830 nM
The estimate for compound 3 lay 23-fold (1.36 log units) below the measured number; the measured number lies above the stated range.
By their numbers in this assay, from the lowest: compound 1; then compound 2; then compound 3.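

In this assay this position proves far less forgiving than the earlier pair suggested: benzylcarbamoyl on the oxygen gives a 25-fold higher number from compound 2 to compound 3 (1.41 log units; beyond the scatter) and a 55-fold higher number from compound 1 to compound 3 (1.74 log units; beyond the scatter) and both steps are large, whereas changing only the group on the double-bonded nitrogen moved the number modestly. Replacing the whole arm therefore matters far more here than changing its end group.

Still open, as far as these compounds go, is whether the loss goes with the benzyl ring or with the carbamoyl link, a question that an ethylcarbamoyl group on this oxygen could help separate. Nothing available here explains the size of this loss.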